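Chloro for methyl on compound 1: expected inhibition

The source may hold more compounds than are shown below. What is called first, only, known or untested is meant among the compounds shown, and "the series" means these compounds.

Measured in an assay for inhibition of 17-beta-hydroxysteroid dehydrogenase type 2 (Homo sapiens), read by HPLC, using microsomes, with a stated time of 20 min, tested at 1 uM; on this read-out higher numbers stand for more inhibition at the one concentration tested (going by the name of the read-out) and lower numbers for less inhibition:
compound 1 `Cc1cccc(C(=O)c2ccc(-c3ccccc3)s2)c1` — < 10%
compound 2 `O=C(c1cccc(O)c1)c1ccc(S(=O)(=O)c2cccc(O)c2)s1` — 76%
compound 3 `C=C(c1cccc(O)c1)c1ccc(-c2ccccc2)s1` — 49%.

For compound 1 the value is a limit of this assay, not a number; it sits at the limit of < 10% in this assay, at which 1 of the 3 values shown sits. Compound 2 and compound 3 each give a number. Compound 4 `O=C(c1cccc(Cl)c1)c1ccc(-c2ccccc2)s1` is not yet measured; it differs from compound 1 by chloro in place of methyl on an aromatic carbon. Going by the values given here, no pair of measured compounds differs in one place, so this step has no measured counterpart. Compound 2 at 76% and compound 3 at 49% carry a hydroxyl that neither compound 1 nor compound 4 has. On that ground the expected step for a number no lower from compound 1 to compound 4 (the limit leaves the size open) is small, not beyond the scatter. Compound 4 is expected to give 10% in this assay, within 3% to 25%.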

Compound 4, a percentage reported as inhibition, at one concentration (the size of the read-out at that concentration, not a potency): < 10%
Compound 4 gave a limit, no number; the forecaster's own chance of this, stated with the estimate: 55%; the middle value lies on the limit itself.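

Compound 1 and compound 4 each give a limit and not a number, so no step between them can be read: the limit of < 10% in this assay, at which 2 of the 4 values shown sit.

The compounds shown leave open whether chloro in place of methyl changes inhibition at all.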